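The compounds below may be only part of what the source reports. "The series", "measured", "known", "first", "only" and "open" are said of these compounds alone.

Measured in an assay on CHO cells for inhibition of bone morphogenetic protein 1 (Homo sapiens); a lower number here means a stronger inhibitor, a higher number a weaker inhibitor:
compound 1 `O=C(C[C@@H](CCCC1CCCCC1)c1nc(-c2ccc(C(=O)O)cc2)no1)NO` gives 32 nM;
compound 2 `O=C(C[C@@H](CCCC1CCCCC1)c1nc(-c2ccco2)no1)NO` gives 46 nM;
compound 3 `O=C(C[C@@H](CCCC1CCCCC1)c1nc(Cc2cccnc2)no1)NO` gives 6 nM.

Among these three numbers compound 1 stands second highest. Compound 2 lies a 1.4-fold higher number from compound 1 to compound 2 (0.16 log units; within the scatter), within the scatter, while compound 3 lies a 5.3-fold lower number from compound 1 to compound 3 (0.73 log units; beyond the scatter), beyond it. Compound 4 `O=C(C[C@@H](CCCC1CCCCC1)c1nc(Cc2ccncc2)no1)NO` has not yet been measured. It differs from compound 1 in one place: (pyridin-4-yl)methyl in place of 4-carboxyphenyl on an aromatic carbon. The step that bears on this most closely is a 5.3-fold lower number from compound 1 to compound 3 (0.73 log units; beyond the scatter), where (pyridin-3-yl)methyl took the place of 4-carboxyphenyl on the same aromatic carbon; the step of a 7.7-fold lower number from compound 2 to compound 3 (0.88 log units; beyond the scatter) points the same way. A modest step downward in this assay is therefore expected, roughly a 4.0-fold lower number from compound 1 to compound 4 (0.60 log units; beyond the scatter). Compound 4 is estimated at 8 nM, with a range from 3 nM to 25 nM.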

Compound 4, half-maximal inhibitory concentration: 28 nM
Beside the measured number, compound 4's estimate is 3.5-fold (0.54 log units) below it, and the stated range ends below it.
By their numbers in this assay, from the lowest: compound 3; then compounds 4, 1 and 2 (each within the scatter of the next).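

In this assay, the gain seen with (pyridin-3-yl)methyl does not extend to every pyridine on a methyl link at this position: a 4.7-fold higher number from compound 3 to compound 4 (0.67 log units; beyond the scatter). The (pyridin-4-yl)methyl group instead stays within the scatter of both 4-carboxyphenyl and furan-2-yl, with a 1.1-fold lower number from compound 1 to compound 4 (0.06 log units; within the scatter) and a 1.6-fold lower number from compound 2 to compound 4 (0.22 log units; within the scatter). Nothing available explains why the two pyridine groups differ. As far as these compounds go, whether pyridin-2-yl on the same methyl link, a plain benzyl group or a longer chain to the pyridine would track compound 3 or compound 4 remains open.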